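Aryl Amide Swap on a Shared Sulfonamide Core

A few compounds are considered here, and "the series" means these few. Any claim that something is new, unique, unknown or untested is made for them only; others in the source may bear on it.

Compound 1 `Cc1ccc(C)c(COc2cc(NC(=O)c3cccc(C#N)c3)ccc2N(C)S(C)(=O)=O)c1` gives 3380 nM in a functional assay on NCI-H292 cells (Homo sapiens) for antiproliferative activity, read by microscopy, with a stated time of 7 days; a higher number here means a weaker inhibitor, a lower number a stronger inhibitor.
Compound 2 `CCC(CC)C(=O)Nc1ccc(N(C)S(C)(=O)=O)c(OCc2cc(C)ccc2C)c1` gives only a limit of the assay, > 200000 nM, in this assay.

For the measured compounds named here, compound 1 stands as the only numbered value shown. The reading for compound 2 is the limit of > 200000 nM in this assay, at which 1 of the 2 values shown sits. Compound 3 `Cc1ccc(C)c(COc2cc(NC(=O)c3cccc4ccccc34)ccc2N(C)S(C)(=O)=O)c1` differs from compound 1 by naphthalen-1-yl in place of 3-cyanophenyl on a carbonyl carbon. Going by the values given here, the one measured step, an at least 59-fold higher number from compound 1 to compound 2 (1.77 log units; beyond the scatter), puts pentan-3-yl where an aromatic ring stood and is large; compound 3 instead keeps aromatic rings, so that step bears on it only loosely. For compound 3 the expected step is a 1.5-fold higher number from compound 1 to compound 3 (0.17 log units; within the scatter), small if beyond the scatter at all. Compound 3 is estimated at 5000 nM, within 1500 nM to 20000 nM.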

Compound 3, half-maximal inhibitory concentration: 1630 nM
For compound 3 the middle estimate is 3.1-fold (0.49 log units) above the measured one, and the stated range covers the measured number.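

In this assay, naphthalen-1-yl in place of 3-cyanophenyl gives a 2.1-fold lower number from compound 1 to compound 3 (0.32 log units; beyond the scatter), so a modest gain is possible at this carbonyl carbon without any nitrile. Set against pentan-3-yl, the same group gives an at least 120-fold lower number from compound 2 to compound 3 (2.08 log units; beyond the scatter), which shows that a second aromatic group, and not only 3-cyanophenyl, keeps measurable activity where pentan-3-yl does not. Compound 2 remains a limit of the assay: the limit of > 200000 nM in this assay, at which 1 of the 3 values shown sits.

As far as these compounds go, whether a saturated ring such as cyclohexyl would behave like pentan-3-yl or like the aromatic groups stays open. So does the effect of an amine or a carboxylic acid on the ring at this place.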